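From sulfonyl to phenylcarbamoyl on a ring nitrogen

The compounds below may be only part of what the source reports. "The series", "measured", "known", "first", "only" and "open" are said of these compounds alone.

In an ADME assay on MOLT-4 cells (Homo sapiens) for inhibition, with a stated time of 4 days (on this read-out lower numbers stand for an effect already at smaller amounts and higher numbers for an effect only at larger amounts of compound), compound 1 (`CN1CCN(c2ccc(C(=O)Nc3n[nH]c4c3CN(C(=O)c3ccccc3)C4)cc2)CC1`) gives 540 nM and compound 2 (`Cc1ccc(S(=O)(=O)N2Cc3[nH]nc(NC(=O)c4ccc(N5CCN(C)CC5)cc4)c3C2)cc1`) gives 940 nM, two values within the scatter of each other. Compound 3 (`CN1CCN(c2ccc(C(=O)Nc3n[nH]c4c3CN(C(=O)Nc3ccccc3)C4)cc2)CC1`) carries phenylcarbamoyl in place of (4-methylphenyl)sulfonyl on an amine nitrogen in a ring. For the measured compounds named here, the only measured step at this nitrogen, a 1.7-fold higher number from compound 1 to compound 2 (0.24 log units; within the scatter), stayed within the scatter, so no step beyond the scatter is expected in this assay. The expected step is a 1.6-fold lower number from compound 2 to compound 3 (0.19 log units; within the scatter). For compound 3 the estimated value is 600 nM, with an expected range of 220 nM to 1600 nM.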

Compound 3, half-maximal effective concentration: 3550 nM
Compound 3: the middle estimate sits 5.9-fold (0.77 log units) below what was measured; measured number outside the range, above it.
By their numbers in this assay, from the lowest: compounds 1 and 2 (each within the scatter of the next); then compound 3.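

In this assay the amine nitrogen in a ring proves sensitive to what it carries, with a 3.8-fold higher number from compound 2 to compound 3 (0.58 log units; beyond the scatter) and a 6.6-fold higher number from compound 1 to compound 3 (0.82 log units; beyond the scatter) pointing the same way. Benzoyl and (4-methylphenyl)sulfonyl did not separate on this read-out, whereas phenylcarbamoyl stands apart from both. Anilino in place of phenyl on a carbonyl carbon is a single-atom insertion, yet it is enough to move the number beyond the scatter. On these data alone, whether methylcarbamoyl or a plain benzyl group would side with compound 3 or with compounds 1 and 2 stays open. Nothing available gives a reason for this rise.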